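This account rests on a few compounds, and the source may have more. Where it says the series, first, only, none or still open, it means among the compounds named here.

Measured so far in an ADME assay on HEK-293T cells (Homo sapiens) for cytotoxicity, read by MTT assay, with a stated time of 24 h; a higher number here means that more compound is tolerated, a lower number that less compound is tolerated:
compound 1, `O=C(c1ccc(Cl)cc1)n1c(-c2cn(-c3ccccc3)nc2-c2ccc(C(F)(F)F)cc2)nc2ccccc21`: 181000 nM
compound 2, `Cc1cncc(C(=O)n2c(-c3cn(-c4ccccc4)nc3-c3ccc(C(F)(F)F)cc3)nc3ccccc32)c1`: 123000 nM

In this assay, among the compounds with values here, compound 2 stands at the lower of the two numbers, with compound 1 its only neighbour, and the step of a 1.5-fold lower number from compound 1 to compound 2 (0.17 log units; within the scatter) lies within the scatter. Compound 3, `O=C(c1ccccc1)n1c(-c2cn(-c3ccccc3)nc2-c2ccc(C(F)(F)F)cc2)nc2ccccc21`, differs from compound 2 by phenyl in place of 5-methylpyridin-3-yl on a carbonyl carbon. Within the data shown here, the only step measured so far, a 1.5-fold lower number from compound 1 to compound 2 (0.17 log units; within the scatter), also swapped the group on this carbonyl carbon and stayed within the scatter, so no step beyond the scatter is expected here either. Compound 3 is therefore estimated at 150000 nM, between 80000 nM and 280000 nM, which means an expected step of a 1.2-fold higher number from compound 2 to compound 3 (0.09 log units; within the scatter).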

Compound 3, half-maximal cytotoxic concentration: 168000 nM
For compound 3 the middle estimate is 1.1-fold (0.05 log units) below the measured one; measured number inside the range.
By their numbers in this assay, from the lowest: compounds 2, 3 and 1 (each within the scatter of the next).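

In this assay, phenyl in place of 5-methylpyridin-3-yl on the carbonyl carbon gives a 1.4-fold higher number from compound 2 to compound 3 (0.14 log units; within the scatter) and stays within the scatter. Hydrogen in place of chloro on the aromatic carbon gives a 1.1-fold lower number from compound 1 to compound 3 (0.03 log units; within the scatter), also within the scatter, so this second change, seen separately for the first time, does not separate the compounds either. Nothing available bears on why these numbers stay so close. Open, from the compounds shown here alone, is whether an amine, a carboxylic acid or a longer chain on this carbonyl carbon would give a step beyond the scatter.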